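The source may report more compounds than this note shows. Statements on the series, on what has been measured and on what is new or still open speak of the compounds shown alone.

Compound 1 `CCCN(CC#Cc1cc2ncnc(Nc3ccc(OCc4cccc(F)c4)c(Cl)c3)c2s1)CCC` carries a 3-(dipropylamino)prop-1-yn-1-yl group on its core. In an ADME assay on HepG2 cells (Homo sapiens) for cytotoxicity (on this read-out lower numbers stand for higher toxicity in this test and higher numbers for lower toxicity in this test), compound 1 gives 26.5 uM. Compound 2 `CN(C)CC#Cc1cc2ncnc(Nc3ccc(OCc4cccc(F)c4)c(Cl)c3)c2s1` differs from compound 1 by dimethylamino in place of dipropylamino on a saturated chain carbon bound to a triple-bonded carbon. For compound 2 the result in this assay is a limit of the assay, > 32 uM. The change from compound 1 to compound 2 thus brought an at least 1.2-fold higher number from compound 1 to compound 2 (0.08 log units; that floor lies within the scatter), a step whose floor is set by the limit of > 32 uM in this assay, at which 1 of the 3 values shown sits.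

Compound 3 `CCCN(CC#Cc1cc2c(Nc3ccc(OCc4cccc(F)c4)c(Cl)c3)ncnc2s1)CCC` is built from the same atoms as compound 1, joined differently; how its core differs from the core of compound 1 is not broken down here. In this assay compound 3 gives 17 uM, the lowest of the two numbers available, with compound 1 nearest at a gap that lies within the scatter.

Compound 4 `CN(C)CC#Cc1cc2c(Nc3ccc(OCc4cccc(F)c4)c(Cl)c3)ncnc2s1` has not yet been measured. It stands to compound 3 as compound 2 stands to compound 1: dimethylamino in place of dipropylamino on a saturated chain carbon bound to a triple-bonded carbon, the same change at the same place. Among the measured compounds shown here, the only measured instance of this change, from compound 1 to compound 2, moved the number up to the limit of the assay; how far beyond the floor of an at least 1.2-fold higher number from compound 1 to compound 2 (0.08 log units; that floor lies within the scatter) it went is not known. On that single step the expectation rests. Compound 4 is expected to show a step upward, estimated as a 1.8-fold higher number from compound 3 to compound 4 (0.25 log units; within the scatter), with a real chance that the assay again reports only a limit. The estimate for compound 4 in this assay is 30 uM, between 15 uM and 60 uM.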

Compound 4, half-maximal toxic concentration: > 32 uM
Compound 4: no number, only a limit; the forecaster's own chance of this, stated with the estimate: 45%; at least 1.0-fold (0.02 log units) between middle value and limit.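

In this assay compound 4 gives > 32 uM, which is a limit of the assay and not a number. Dimethylamino in place of dipropylamino on the core of compound 3 therefore comes with an at least 1.8-fold higher number from compound 3 to compound 4 (0.27 log units; that floor lies within the scatter), and this step, like the earlier one on the core of compound 1, is known only as a floor that lies within the scatter, so the two agree in form without either establishing a real change: the same change on two cores in this assay, an at least 1.2-fold higher number (0.08 log units; that floor lies within the scatter) from compound 1 to compound 2 and an at least 1.8-fold higher number (0.27 log units; that floor lies within the scatter) from compound 3 to compound 4; the limit leaves it open whether they differ What this does not show is whether the change carries over from one core to the other with the same size, or whether on either core it truly reaches beyond the scatter, since both dimethylamino compounds end at a limit rather than at a number: the limit of > 32 uM in this assay, at which 2 of the 4 values shown sit.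

The compounds shown leave open how other amines, such as diethylamino, piperidine or morpholine, would read in this assay on the same saturated chain carbon bound to a triple-bonded carbon. They also leave open whether a primary amine or a longer chain at that place would follow dipropylamino or dimethylamino on either core.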